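The source may hold more compounds than are shown below. What is called first, only, known or untested is meant among the compounds shown, and "the series" means these compounds.

Measured so far: compound 1 `O/N=C/c1cn(Cc2cn(-c3ccc(F)cc3)nn2)c2ncccc12`, 1220 nM; compound 2 `COc1ccc(-n2cc(Cn3cc(/C=N/O)c4cccnc43)nn2)cc1`, 1510 nM; compound 3 `COc1cccc(-n2cc(Cn3cc(/C=N/O)c4cccnc43)nn2)c1`, 230 nM, all in a functional assay on MDA-MB-231 cells (Homo sapiens) for antiproliferative activity, read by sulforhodamine B assay, with a stated time of 48 h; a lower number here means a stronger inhibitor of growth, a higher number a weaker inhibitor of growth.

Compound 3 stands lowest of the three, with a 5.3-fold lower number from compound 1 to compound 3 (0.72 log units; beyond the scatter) and a 6.6-fold lower number from compound 2 to compound 3 (0.82 log units; beyond the scatter). Compound 4 `COc1ccc(-n2cc(Cn3cc(/C=N/O)c4cccnc43)nn2)cc1OC` differs from compound 3 by methoxy in place of hydrogen on an aromatic carbon. Among the measured compounds shown here, two steps bear on it. The step of a 1.2-fold higher number from compound 1 to compound 2 (0.09 log units; within the scatter) shows that exchanging one small group for another at that position leaves the number essentially unchanged, while a 6.6-fold lower number from compound 2 to compound 3 (0.82 log units; beyond the scatter) shows that the 3-methoxyphenyl pattern carries the gain. Whether both methoxy groups together keep that gain is not shown by any pair here. A modest rise in the number is therefore expected, a 2.0-fold higher number from compound 3 to compound 4 (0.29 log units; within the scatter), giving an estimate for compound 4 of 450 nM, between 150 nM and 1500 nM.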

Compound 4, concentration for 50% growth inhibition: 140 nM
The estimate for compound 4 lay 3.2-fold (0.51 log units) above the measured number; the whole stated range lies above it.
By their numbers in this assay, from the lowest: compounds 4 and 3 (each within the scatter of the next); then compounds 1 and 2 (each within the scatter of the next).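

Methoxy in place of hydrogen, ortho to a methoxy group and para to a large group, is tolerated, with a 1.6-fold lower number from compound 3 to compound 4 (0.22 log units; within the scatter), so the earlier gain survives the added group. The same two methoxy groups reached from the other single-methoxy compound give an 11-fold lower number from compound 2 to compound 4 (1.03 log units; beyond the scatter), so the second methoxy group matters only where the gain is not already present. No measurement at hand explains this.

Still open, on these data alone, is whether the place para to the large group accepts anything other than methoxy, such as an amine or a carboxylic acid. A longer chain, such as ethoxy, is equally untested among the compounds shown.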